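This account rests on a few compounds, and the source may have more. Where it says the series, first, only, none or still open, it means among the compounds named here.

Of the compounds shown here, three have so far been measured in an assay on microsomes from liver for inhibition of sterol O-acyltransferase 1 (Rattus norvegicus); on this read-out higher numbers stand for weaker inhibition and lower numbers for stronger inhibition. Compound 1 `CC1=CC(=O)OC(CSc2nc(-c3cccc(Cl)c3)c(-c3cccc(Cl)c3)[nH]2)C1` gives 440 nM. Compound 2 `CO[C@]1(C)C[C@H](O)C[C@@H](CSc2nc(-c3ccccc3)c(-c3ccccc3)[nH]2)O1` gives 30 nM, and compound 3 `CO[C@H]1C[C@H](O)C[C@@H](CSc2nc(-c3ccccc3)c(-c3ccccc3)[nH]2)O1` gives 90 nM. Compound 3 thus stands second highest of the three numbers: compound 2 is nearest to it, and compound 1 lies furthest away. Among the compounds with values here, the only measured step between two compounds that differ in a single place is a 3.0-fold higher number from compound 2 to compound 3 (0.48 log units; beyond the scatter), where hydrogen stands in place of methyl on a saturated ring carbon.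

Compound 4 `c1ccc(-c2nc(SCC3OCCO3)[nH]c2-c2ccccc2)cc1` has not yet been measured in this assay. It differs from compound 3 by a group of 5 heavy atoms (3 carbon, 2 oxygen; one five-membered non-aromatic ring with 2 hetero atoms) in place of a group of 9 heavy atoms (6 carbon, 3 oxygen; one six-membered non-aromatic ring with 1 hetero atom), on a saturated chain carbon bound to a sulfur. Within the data shown here, the one measured step is a small change within the same ring and so bears only loosely on this far larger exchange, in which the whole six-membered ring, carrying the one hydrogen-bond donor, gives way to a smaller ring with none. Among the measured compounds shown here, no measured pair isolates such an exchange. Compound 1 has the highest number of the three, but it differs from compounds 2 and 3 in more than one place, so it offers only a faint hint. The expectation for compound 4 is therefore a step of a 3.3-fold higher number from compound 3 to compound 4 (0.52 log units; beyond the scatter) towards weaker inhibition, held with wide uncertainty. Compound 4 is expected to give about 300 nM in this assay, between 80 nM and 1200 nM.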

Compound 4, half-maximal inhibitory concentration: 530 nM
The estimate for compound 4 lay 1.8-fold (0.25 log units) below the measured number; the range from low to high includes it.
By their numbers in this assay, from the lowest: compound 2; then compound 3; then compounds 1 and 4 (each within the scatter of the next).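

At the saturated chain carbon bound to a sulfur, exchanging the whole six-membered ring group for 1,3-dioxolan-2-yl gives, in this assay, a 5.9-fold higher number from compound 3 to compound 4 (0.77 log units; beyond the scatter), so inhibition at this position depends on more than the small edit seen in a 3.0-fold higher number from compound 2 to compound 3 (0.48 log units; beyond the scatter), which only removed a methyl from a saturated ring carbon. The new step is harder to interpret, however, since several things change together: the ring size, the number of heavy atoms, the hydrogen-bond donor that the leaving group has and 1,3-dioxolan-2-yl lacks, and the defined stereocentres that 1,3-dioxolan-2-yl does not carry. Nothing available here explains why the inhibition weakens with this exchange.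

The compounds shown leave open which of these differences matters, as no pair changes the ring size alone or the hydrogen-bond donor alone. They also leave open how this position would respond to a group of another kind, such as an amine, a carboxylic acid or a simple open carbon chain in place of the ring.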